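The compounds below may be only part of what the source reports. "The series", "measured", "known", "first", "only" and "open" are said of these compounds alone.

Compound 1 `COC(=O)C[C@H]1C[C@H](O)[C@@H](C)[C@@H](c2ccc(C)cc2)N1`: 330000 nM
Compound 2 `COC(=O)C[C@H]1C[C@@H](O)[C@@H](C)[C@@H](c2ccc(C(C)C)cc2)N1`: 110000 nM

In a functional assay on DU-145 cells (Homo sapiens) for cytotoxicity, read by MTT assay (on this read-out lower numbers stand for stronger inhibition and higher numbers for weaker inhibition), compound 2 gives 110000 nM, the lower of the two numbers, and its gap to compound 1 lies beyond the usual scatter. Compound 3 `COC(=O)C[C@H]1C[C@H](O)[C@@H](C)[C@@H](c2ccc(C(C)C)cc2)N1` has not yet been measured. Its difference from compound 2 is purely one of spatial arrangement: the two compounds have the same atoms and bonds and differ only in configuration as drawn: 1 of 4 stereo elements differ; a stereocentre at a saturated ring carbon is drawn R in compound 2 and S in compound 3. A stereocentre at a saturated ring carbon is drawn R in compound 2 and S in compound 3. Within the data shown here, no measured pair shows what this kind of change does in this assay, so any forecast is uncertain. Compound 1 at 330000 nM and compound 2 at 110000 nM both sit at high numbers, which suggests weak inhibition is likely to continue. A small move toward a higher number, probably within the scatter, is expected for a 1.5-fold higher number from compound 2 to compound 3 (0.16 log units; within the scatter). For compound 3, the estimated value is 160000 nM, with an expected range of 60000 nM to 400000 nM.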

Compound 3, half-maximal inhibitory concentration: 27400 nM
Beside the measured number, compound 3's estimate is 5.8-fold (0.77 log units) above it; the whole stated range lies above it.
By their numbers in this assay, from the lowest: compound 3; then compound 2; then compound 1.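

In this assay, switching one stereocentre at a saturated ring carbon from R to S gives a 4.0-fold lower number from compound 2 to compound 3 (0.60 log units; beyond the scatter) and so shows that the configuration at this carbon matters on its own. The shift can be assigned to this stereocentre alone, because nothing else separates the pair: the fact that compounds 2 and 3 differ only in the configuration as drawn. With that carbon drawn the same way, isopropyl in place of methyl on an aromatic carbon goes with a 12-fold lower number from compound 1 to compound 3 (1.08 log units; beyond the scatter) and can now be read cleanly, whereas compound 1 and compound 2 differ in both places at once.

On these data alone, whether the same switch would matter as much with methyl on the aromatic ring remains open. So does the effect of a longer chain such as tert-butyl at that place, or of a carboxylic acid in place of the methyl ester.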